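This account rests on a few compounds, and the source may have more. Where it says the series, first, only, none or still open, it means among the compounds named here.

Compound 1 `CCCCCc1ccc(NS(=O)(=O)c2ccc(N3CCNC3=O)cc2)cc1` gives 870 nM in a functional assay on M21 cells (Homo sapiens) for antiproliferative activity, read by sulforhodamine B assay, with a stated time of 48 h; on this read-out lower numbers stand for stronger inhibition and higher numbers for weaker inhibition.
Compound 2 `O=C1NCCN1c1ccc(S(=O)(=O)Nc2ccc(OC(F)F)cc2)cc1` gives 410 nM in this assay.
Compound 3 `O=C1NCCN1c1ccc(S(=O)(=O)Nc2ccc(F)c(F)c2)cc1` gives 220 nM in this assay.

Among these three numbers, compound 2 stands second highest. Compound 3 lies within the usual scatter of compound 2, so the two cannot be told apart; compound 1 lies beyond the scatter, with the higher number.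

Compound 4 `O=C1NCCN1c1ccc(S(=O)(=O)Nc2ccc(C3CCCCC3)cc2)cc1` keeps the shared core of compound 2 and changes one group: cyclohexyl in place of difluoromethoxy on an aromatic carbon.

Within the data shown here, only one measured step touches this position. The change a 2.1-fold lower number from compound 1 to compound 2 (0.33 log units; beyond the scatter) removed a carbon chain and brought in the very difluoromethoxy group that now leaves again. In compound 4 the group that enters is a six-membered ring of carbon only, which in its make-up stands nearer to the pentyl of compound 1 than to the difluoromethoxy of compound 2. The most natural expectation is therefore a return toward the number of compound 1, that is a modest rise in this assay, though a ring is not a chain and the step could also fall within the scatter.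

For compound 4 the expected step is a 1.7-fold higher number from compound 2 to compound 4 (0.23 log units; within the scatter). The estimate for compound 4 in this assay is 700 nM, with a range from 300 nM to 1700 nM.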

Compound 4, half-maximal inhibitory concentration: > 1000 nM
Compound 4 ended at the assay's limit (the forecaster's own chance of this, stated with the estimate: 3%); middle value at least 1.4-fold (0.15 log units) from the limit.
By their numbers in this assay, from the lowest: compounds 3 and 2 (each within the scatter of the next); then compound 1. At a limit, above all of these: compound 4.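

For compound 4, > 1000 nM in this assay is a limit of the assay and not a number: the limit of > 1000 nM in this assay, at which 1 of the 4 values shown sits.

Even so, the comparison with compound 2 can be read, and it shows that this aromatic carbon, para to a large group, does not treat the two groups alike: cyclohexyl in place of difluoromethoxy gives an at least 2.4-fold higher number from compound 2 to compound 4 (0.38 log units; beyond the scatter). Together with a 2.1-fold lower number from compound 1 to compound 2 (0.33 log units; beyond the scatter), this means that both carbon-only groups shown here, the pentyl chain and the cyclohexyl ring, carry higher numbers, and so weaker inhibition, than difluoromethoxy, while the comparison of the chain with the ring gives only an at least 1.1-fold higher number from compound 1 to compound 4 (0.06 log units; that floor lies within the scatter), so it cannot say whether the ring does worse than the chain.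

The compounds shown leave open which part of the difluoromethoxy group matters, as the oxygen and both fluorines leave together in this single change, and a ring enters at the same time. A methoxy group, which keeps the oxygen without fluorine, and an amine or a carboxylic acid on the same carbon would each test this position in a different way.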